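Thiazole to Butyl-Imidazole: A Step Expected Within Scatter

The compounds below may be only part of what the source reports. "The series", "measured", "known", "first", "only" and "open" are said of these compounds alone.

Compound 1, `Cc1ccc(CN2CCN(c3cccc4[nH]c(-c5ccc(C(C)(C)C)cc5)nc34)CC2)o1`: 705 nM
Compound 2, `Cn1cnc(CN2CCN(c3cccc4[nH]c(-c5ccc(C(C)(C)C)cc5)nc34)CC2)c1`: 33 nM
Compound 3, `Cc1nc(C)c(CN2CCN(c3cccc4[nH]c(-c5ccc(C(C)(C)C)cc5)nc34)CC2)s1`: 27 nM

In an assay on isolated protein for displacement of a labelled ligand from Gonadotropin-releasing hormone receptor (Homo sapiens) (on this read-out lower numbers stand for stronger inhibition and higher numbers for weaker inhibition), compound 3 gives the lowest of the three numbers. Compound 2 sits close to it, as the step of a 1.2-fold lower number from compound 2 to compound 3 (0.09 log units; within the scatter) lies within the scatter, so no order between compound 2 and compound 3 can be read from these numbers. Compound 1 stands far from both: the steps of a 21-fold lower number from compound 1 to compound 2 (1.33 log units; beyond the scatter) and a 26-fold lower number from compound 1 to compound 3 (1.42 log units; beyond the scatter) are large and beyond the scatter.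

Compound 4, `CCCCn1cnc(CN2CCN(c3cccc4[nH]c(-c5ccc(C(C)(C)C)cc5)nc34)CC2)c1C`, has not been measured. It differs from compound 3 by 1-butyl-5-methyl-1H-imidazol-4-yl in place of 2,4-dimethyl-1,3-thiazol-5-yl on a saturated chain carbon bound to an amine nitrogen in a ring. The measured steps that bear on this are the two that already swap the group on the same saturated chain carbon: compound 2 carries a 1-methyl-1H-imidazol-4-yl and compound 3 a 2,4-dimethyl-1,3-thiazol-5-yl, and the step of a 1.2-fold lower number from compound 2 to compound 3 (0.09 log units; within the scatter) between them is within the scatter. Among the measured compounds shown here, compound 4 carries an imidazole of the same kind with a 1-butyl and a 5-methyl group added; no measured pair tests those additions.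

The expectation for compound 4 in this assay is therefore no step beyond the scatter, a 1.3-fold higher number from compound 3 to compound 4 (0.11 log units; within the scatter), with the estimate 35 nM and a range from 10 nM to 120 nM.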

Compound 4, half-maximal inhibitory concentration: 46 nM
Compound 4: middle estimate off by 1.3-fold (0.12 log units), on the low side, and the stated range covers the measured number.
By their numbers in this assay, from the lowest: compounds 3, 2 and 4 (each within the scatter of the next); then compound 1.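

In this assay, a 1.7-fold higher number from compound 3 to compound 4 (0.23 log units; within the scatter) and a 1.4-fold higher number from compound 2 to compound 4 (0.14 log units; within the scatter) both lie within the scatter, so the saturated chain carbon bound to an amine nitrogen in a ring can carry the 1-butyl-5-methyl-1H-imidazol-4-yl group without a readable change from the smaller 1-methyl-1H-imidazol-4-yl or 2,4-dimethyl-1,3-thiazol-5-yl groups. The distance from the 5-methylfuran-2-yl group also survives this added bulk, with a 15-fold lower number from compound 1 to compound 4 (1.19 log units; beyond the scatter) lying well beyond the scatter, so compound 1 remains the only one of the four that stands apart. Nothing measured here offers a reason for either the tolerance of the butyl chain or the gap to compound 1.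

The butyl and methyl groups arrive together in compound 4, so the compounds shown cannot separate what each one contributes, and the two could even be offsetting each other. As far as these compounds go, it also remains open how much further this position stretches, for example whether a chain ending in an amine or a carboxylic acid in place of the butyl would stay within the scatter of compound 4.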